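Thiophene substituent swap in a weakly inhibiting fused-ring series

A few compounds are considered here, and "the series" means these few. Any claim that something is new, unique, unknown or untested is made for them only; others in the source may bear on it.

Measured compounds: compound 1 `O=C([C@H]1Cc2cc(Cl)cc(-c3ccnc4ccsc34)c2O1)N1CCNCC1`, > 40000 nM; compound 2 `O=C([C@H]1Cc2cc(Cl)cc(-c3ccnc4cc(Cn5cnccc5=O)sc34)c2O1)N1CCNCC1`, > 5000 nM.

Both measured values in an assay on isolated protein for inhibition of ubiquitin carboxyl-terminal hydrolase 47 (Homo sapiens) (on this read-out higher numbers stand for weaker inhibition and lower numbers for stronger inhibition), are limits of the assay, not numbers. Compound 1 returns only the limit > 40000 nM in this assay. Compound 2 likewise returns only the limit > 5000 nM in this assay, so compound 2 stands at a limit and nowhere on a readable scale. Within the data shown here, the only computed step, a step that the two limits leave unreadable from compound 1 to compound 2, is therefore unreadable: the limit of > 40000 nM in this assay, at which 1 of the 2 values shown sits, and the limit of > 5000 nM in this assay, at which 1 of the 2 values shown sits, together leave its size open.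

Compound 3 `O=C([C@H]1Cc2cc(Cl)cc(-c3ccnc4cc(C(O)(CO)CCl)sc34)c2O1)N1CCNCC1` differs from compound 2 by a group of 6 heavy atoms (3 carbon, 2 oxygen, 1 chlorine; no ring) in place of a group of 8 heavy atoms (5 carbon, 2 nitrogen, 1 oxygen; one six-membered aromatic ring with 2 hetero atoms), on an aromatic carbon. The entering group is 1-(chloromethyl)-1,2-dihydroxyethyl, on an aromatic carbon of a five-membered aromatic ring with 1 sulfur, part of a fused or bridged system of two rings, next to the ring sulfur. Among the measured compounds shown here, no measured step bears on this change: the one step, from compound 1 to compound 2, is unreadable, and no further pair is present. The expectation for this assay is therefore no readable step beyond the scatter, in either direction, and compound 3 is estimated to remain at or beyond the limit region of compound 2, with an expected step that the limit leaves unreadable from compound 2 to compound 3.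

Compound 3 is estimated at 20000 nM in this assay, within 5000 nM to 80000 nM.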

Compound 3, half-maximal inhibitory concentration: > 40000 nM
Compound 3 gave a limit, no number; the forecaster's own chance of this, stated with the estimate: 70%; middle value at least 2.0-fold (0.30 log units) away from the limit.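

In this assay, compound 3 returns only a limit, as do compound 1 and compound 2, so no step among these three compounds can be read. The compounds shown leave open how strongly any of them inhibits, and whether placing 1-(chloromethyl)-1,2-dihydroxyethyl on the shared core changes inhibition at all.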